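Swapping the fluorophenyl arm for a five-membered heteroaryl

The source may report more compounds than this note shows. Statements on the series, on what has been measured and on what is new or still open speak of the compounds shown alone.

Measured compounds:
Compound 1, `NCc1cc(F)ccc1CN(Cc1nc2ccccc2[nH]1)C1CCCc2cccnc21`: 219 nM
Compound 2, `NCc1ccc(CN(Cc2nc3ccccc3[nH]2)C2CCCc3cccnc32)c(CN)c1`: 10 nM
Compound 3, `NCc1ccncc1CN(Cc1nc2ccccc2[nH]1)C1CCCc2cccnc21`: 160 nM

In a functional assay on CEM-CCRF cells for antagonist activity at C-X-C chemokine receptor type 4 (Homo sapiens), read by calcium flux (on this read-out higher numbers stand for weaker inhibition and lower numbers for stronger inhibition), compound 1 gives 219 nM, the highest of the three numbers. Compound 3 sits nearest, and the step of a 1.4-fold lower number from compound 1 to compound 3 (0.14 log units; within the scatter) is within the scatter. Compound 2 lies furthest away, with a 22-fold lower number from compound 1 to compound 2 (1.34 log units; beyond the scatter), which comes from an aminomethyl in place of fluoro on an aromatic carbon; the related step of a 16-fold higher number from compound 2 to compound 3 (1.20 log units; beyond the scatter) is likewise large.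

Compound 4, `NCc1sccc1CN(Cc1nc2ccccc2[nH]1)C1CCCc2cccnc21`, has not yet been measured. It differs from compound 1 by a group of 7 heavy atoms (5 carbon, 1 nitrogen, 1 sulfur; one five-membered aromatic ring with 1 hetero atom) in place of a group of 9 heavy atoms (7 carbon, 1 nitrogen, 1 fluorine; one six-membered aromatic ring of carbon only), on a saturated chain carbon bound to an amine nitrogen. Going by the values given here, the step that bears most on it is the one from compound 1 to compound 3, where a different aromatic ring replaced the same fluorophenyl group and the number moved only within the scatter. The large step to compound 2 depends on an added aminomethyl, which compound 4 does not gain, so it offers no guide here.

Compound 4 is therefore expected to show a change of about a 1.1-fold lower number from compound 1 to compound 4 (0.04 log units; within the scatter), that is, no step beyond the scatter. In this assay compound 4 is estimated at 200 nM, with a range from 80 nM to 500 nM.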

Compound 4, half-maximal inhibitory concentration: 60 nM
Beside the measured number, compound 4's estimate is 3.3-fold (0.52 log units) above it, and the stated range ends above it.
By their numbers in this assay, from the lowest: compound 2; then compound 4; then compounds 3 and 1 (each within the scatter of the next).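

In this assay, the group with the five-membered aromatic ring does not behave as a neutral ring swap at this saturated chain carbon bound to an amine nitrogen: it gives a 3.7-fold lower number from compound 1 to compound 4 (0.56 log units; beyond the scatter) and also a 2.7-fold lower number from compound 3 to compound 4 (0.43 log units; beyond the scatter) as a further step beyond the scatter. The earlier ring change, a 1.4-fold lower number from compound 1 to compound 3 (0.14 log units; within the scatter) within the scatter, had suggested that the aromatic ring in this arm could be exchanged with little effect, whereas these steps show that its identity can move the number. The change still does not match the arm carrying a second aminomethyl, as there is a 6.0-fold higher number from compound 2 to compound 4 (0.78 log units; beyond the scatter) and the number stays on the higher side of that compound, and nothing in the data shown accounts for any of these differences.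

The compounds shown leave open whether it is the sulfur or the smaller ring size that goes with the lower number, which a furan ring with oxygen in place of sulfur could help to separate. They also leave open whether adding a second aminomethyl to the five-membered ring would lower the number further, or whether an aminoethyl chain could replace the aminomethyl there.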